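The source may hold more compounds than are shown below. What is called first, only, known or untested is meant among the compounds shown, and "the series" means these compounds.

Two compounds measured in a functional assay (muscle tissue) with Cavia porcellus as the target (on this read-out higher numbers stand for an effect only at larger amounts of compound and lower numbers for an effect already at smaller amounts), frame the question. Compound 1 `COC(=O)C1=C(C)N=C(C)/C(=C(\O)OC)C1c1ccccc1Cl` carries a chloro group on its pendant aromatic ring and gives 2.19 nM. Compound 2 `CCOc1ccccc1C1C(C(=O)OC)=C(C)N=C(C)/C1=C(\O)OC` carries an ethoxy group at the same position and gives 110 nM. For the measured compounds named here, of the two numbers known in this assay, compound 2 stands at the highest, its only neighbour being compound 1, which lies well below it, since a 50-fold higher number from compound 1 to compound 2 (1.70 log units; beyond the scatter).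

Compound 3 `COC(=O)C1=C(C)N=C(C)/C(=C(\O)OC)C1c1ccccc1F` is the next compound, not yet measured. It differs from compound 2 in one place: fluoro in place of ethoxy on an aromatic carbon. Going by the values given here, the only measured step that bears on this change is the one from compound 1 to compound 2, where ethoxy in place of chloro raised the number in this assay by a large margin. Compound 3 reverses the direction of that exchange, going from ethoxy back to a single halogen atom, so a large drop in the number is expected for compound 3, roughly a 22-fold lower number from compound 2 to compound 3 (1.34 log units; beyond the scatter), though it need not reach the value of compound 1. Compound 3 is therefore estimated at 5 nM, with a range from 1.5 nM to 20 nM.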

Compound 3, half-maximal effective concentration: 42.7 nM
Beside the measured number, compound 3's estimate is 8.5-fold (0.93 log units) below it; measured number above the stated range.
By their numbers in this assay, from the lowest: compound 1; then compound 3; then compound 2.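

In this assay, exchanging ethoxy for fluoro gives only a 2.6-fold lower number from compound 2 to compound 3 (0.41 log units; beyond the scatter), whereas exchanging chloro for fluoro gives a 19-fold higher number from compound 1 to compound 3 (1.29 log units; beyond the scatter). At this position, on an aromatic carbon ortho to a large group, a single halogen atom therefore does not by itself bring the number down to that of compound 1: the two halogens are far apart, and compound 3 lies much closer to compound 2 than to compound 1. No measurement of any property of these groups is at hand to account for the difference between fluoro and chloro.

From the compounds shown here alone, it remains open where other groups at this position would fall among the three compounds, for example bromo, methyl, methoxy or trifluoromethyl, and whether a longer chain than ethoxy would raise the number further. The compounds shown also leave open whether the order of chloro, fluoro and ethoxy would hold with these groups on another carbon of the aromatic ring, or with a longer chain in place of the methyl esters of the shared core.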